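The source may report more compounds than this note shows. Statements on the series, on what has been measured and on what is new or still open speak of the compounds shown alone.

Working notes on the series. Compound 1 `CS(=O)(=O)Nc1ccc(-c2nc3cc(NS(=O)(=O)c4ccc(Cl)s4)ccc3o2)cc1` carries a chlorothiophene sulfonyl group and a methanesulfonamide on the pendant phenyl; compound 2 `C=Cc1ccc(S(=O)(=O)Nc2ccc3oc(-c4ccccc4)nc3c2)cc1` and compound 3 `O=S(=O)(Nc1ccc2oc(-c3ccccc3)nc2c1)c1ccc(C(F)(F)F)cc1` share the core with an unsubstituted pendant phenyl and differ only in the aryl sulfonyl group. In an assay on cells for inhibition of HSP60/HSP10 (Homo sapiens), with a stated time of 60 min (on this read-out lower numbers stand for stronger inhibition and higher numbers for weaker inhibition), compound 1 gives 43000 nM. Compound 2 gives only a limit of the assay in this assay, > 100000 nM. Compound 3 likewise gives only a limit, > 100000 nM. Compound 2 therefore stands at the limit, and so does compound 3, which is the limit of > 100000 nM in this assay, at which 2 of the 3 values shown sit. Within the data shown here, the single measured step on this core, a step that the two limits leave unreadable from compound 2 to compound 3, cannot be sized because the limit of > 100000 nM in this assay, at which 2 of the 3 values shown sit, hides both ends. Compound 4 `O=S(=O)(Nc1ccc2oc(-c3ccccc3)nc2c1)c1cccc(Cl)c1` differs from compound 2 by 3-chlorophenyl in place of 4-vinylphenyl on a sulfonyl sulfur. Among the measured compounds shown here, no readable step bears on this change; the only related step is the unreadable one from compound 2 to compound 3, so no step beyond the scatter can be expected in either direction. Compound 4 is expected at 120000 nM, with a range from 40000 nM to 400000 nM, most likely again reported as a limit. The expected step is estimated as a step that the limit leaves unreadable from compound 2 to compound 4.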

Compound 4, half-maximal inhibitory concentration: > 100000 nM
Compound 4 was reported as a limit; the forecaster's own chance of this, stated with the estimate: 70%; the middle value is on the limit's open side.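

No step can be read between compound 2 and compound 4 in this assay, because both sit at a limit of the assay: the limit of > 100000 nM in this assay, at which 3 of the 4 values shown sit.

Still open, on these data alone, is whether the chlorothiophene sulfonyl group or the methanesulfonamide on the pendant phenyl of compound 1 accounts for its readable value of 43000 nM.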